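Removing a Methoxy Group: Expected Effect on Vero Cell Toxicity

A few compounds are considered here, and "the series" means these few. Any claim that something is new, unique, unknown or untested is made for them only; others in the source may bear on it.

Compound 1 `COc1ccc(Cn2c(SC(C)C(=O)Nc3ccc(C)cc3Cl)nc3ccccc32)cc1` was tested in an ADME assay on Vero cells (Chlorocebus sabaeus) for cytotoxicity, read by MTT assay, with a stated time of 24 h; on this read-out higher numbers stand for lower toxicity in this test and lower numbers for higher toxicity in this test. In this assay compound 1 gives > 75000 nM, which is a limit of the test rather than a measured number. Compound 2 `Cc1nnc(NC(=O)C(C)Sc2nc3ccccc3n2-c2ccc(F)cc2)nc1C` shares much of the same core, but in this assay compound 2 has "not determined" (no result reported), so it offers nothing to compare. Compound 1 therefore stands at the limit of > 75000 nM in this assay, at which 1 of the 2 values shown sits, the only entry with any result. Compound 3 `Cc1ccc(NC(=O)C(C)Sc2nc3ccccc3n2Cc2ccccc2)c(Cl)c1` differs from compound 1 in one place: hydrogen in place of methoxy on an aromatic carbon. Among the compounds with values here, no measured step between two compounds is available to guide the size of this change. A change this small is expected to move the read-out little, if at all, beyond the usual scatter. The step that the limit leaves unreadable from compound 1 to compound 3 is estimated to be essentially none. Compound 3 is expected to give about 80000 nM, within a range of 30000 nM to 200000 nM, and quite likely again only a limit.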

Compound 3, half-maximal cytotoxic concentration: > 75000 nM
Compound 3 gave a limit, no number (the forecaster's own chance of this, stated with the estimate: 70%); the middle value lies beyond the limit too.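

Compound 1 and compound 3 both sit at a limit of the test rather than at a number, so no step can be read between them: the limit of > 75000 nM in this assay, at which 2 of the 3 values shown sit.

From the compounds shown here alone, whether hydrogen in place of methoxy changes the result in this assay at all stays open, as does the size of any such change.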